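The source may report more compounds than this note shows. Statements on the series, on what has been measured and on what is new or still open speak of the compounds shown alone.

Compound 1, `CC1(C)OC(=O)C2(C(=O)O1)[C@@H](c1ccco1)CC(=O)C[C@H]2c1ccccc1`, in an ADME assay on MT2 cells (Homo sapiens) for cytotoxicity (a lower number here means that less compound is tolerated, a higher number that more compound is tolerated), gives > 111000 nM, which is a limit of the assay and not a number.
Compound 2, `COc1cc([C@@H]2CC(=O)C[C@H](c3ccco3)C23C(=O)OC(C)(C)OC3=O)ccc1O`, in this assay gives > 111000 nM, again a limit of the assay.

Because both values are limits, the step from the one to the other, a step that the two limits leave unreadable from compound 1 to compound 2, cannot be given a size in either direction. Compound 2 therefore stands at the limit of > 111000 nM in this assay, at which 2 of the 2 values shown sit, and how far beneath that limit it would actually fall is not shown.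

Compound 3, `COc1ccc([C@@H]2CC(=O)C[C@H](c3ccco3)C23C(=O)OC(C)(C)OC3=O)cc1OC`, is not yet measured. It differs from compound 2 in one place: methyl in place of hydrogen on an oxygen on an aromatic ring.

Among the measured compounds shown here, the only measured step, from compound 1 to compound 2, changes the same aromatic ring as a whole and so bears on this change, but it gives no readable size. No step beyond the usual scatter is expected in this assay; the step from compound 2 to compound 3 is estimated as a step that the limit leaves unreadable from compound 2 to compound 3. Compound 3 is expected to give about 150000 nM, within 60000 nM to 400000 nM, and most likely to be reported once more only as a limit.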

Compound 3, half-maximal cytotoxic concentration: > 111000 nM
Compound 3: no number, only a limit; the forecaster's own chance of this, stated with the estimate: 85%; the middle value does not contradict the limit.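

In this assay compound 3 gives > 111000 nM, which is a limit of the assay and not a number. Among the compounds shown here, no step among compound 1, compound 2 and compound 3 can be read, as all three stand at the same place: the limit of > 111000 nM in this assay, at which 3 of the 3 values shown sit. As far as these compounds go, whether phenyl, 4-hydroxy-3-methoxyphenyl and 3,4-dimethoxyphenyl differ at all in this assay remains open.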